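Replacing Chloro with (2-Hydroxyethyl)amino on the Shared Core

The compounds below may be only part of what the source reports. "The series", "measured", "known", "first", "only" and "open" are said of these compounds alone.

Compound 1 `OC[C@H]1OC(n2cnc3c(Nc4ccccc4)nccc32)[C@H](O)[C@@H]1O`: 4%
Compound 2 `OC[C@H]1OC(n2cnc3c(S)nccc32)[C@H](O)[C@@H]1O`: 6%
Compound 3 `OC[C@H]1OC(n2cnc3c(Cl)nccc32)[C@H](O)[C@@H]1O`: 76%

The three measured compounds share one core and differ only in the group on one aromatic carbon. In a functional assay (Homo sapiens) for inhibition of Nucleic Acid, tested at 100 uM (on this read-out lower numbers stand for less inhibition and higher numbers for more inhibition at the one concentration tested (going by the name of the read-out)), compound 1 gives 4% and compound 2 gives 6%; the step of a number 2 percentage points higher from compound 1 to compound 2 (within the scatter) lies within the scatter. Compound 3, with 76%, stands highest of the three, set apart by a number 72 percentage points higher from compound 1 to compound 3 (beyond the scatter) and a number 70 percentage points higher from compound 2 to compound 3 (beyond the scatter), both beyond the scatter.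

Compound 4 `OCCNc1nccc2c1ncn2C1O[C@H](CO)[C@@H](O)[C@H]1O` changes compound 3 in one place: (2-hydroxyethyl)amino in place of chloro on an aromatic carbon. Among the compounds with values here, the steps that bear on this are a number 72 percentage points higher from compound 1 to compound 3 (beyond the scatter) and a number 70 percentage points higher from compound 2 to compound 3 (beyond the scatter): each time chloro stood in place of another group on that carbon, the number was far higher, and compound 1, carrying anilino there, gave only 4%. A large drop is therefore expected, a number 68 percentage points lower from compound 3 to compound 4 (beyond the scatter). Compound 4 is estimated at 8%, within 0% to 30%.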

Compound 4, a percentage reported as inhibition, at one concentration (the size of the read-out at that concentration, not a potency): 0%
Compound 4: the middle estimate sits 8 percentage points above what was measured, and the stated range covers the measured number.
By their numbers in this assay, from the lowest: compounds 4, 1 and 2 (each within the scatter of the next); then compound 3.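

In this assay the step to (2-hydroxyethyl)amino is a number 76 percentage points lower from compound 3 to compound 4 (beyond the scatter) and so extends the low numbers seen with anilino and sulfanyl to an open-chain group with no ring. Compound 4 does not separate from the other two, with a number 6 percentage points lower from compound 2 to compound 4 (within the scatter) and a number 4 percentage points lower from compound 1 to compound 4 (within the scatter) on the same read-out, so 2-hydroxyethyl in place of phenyl on the nitrogen changes nothing that can be read here. Nothing measured here speaks to why chloro alone stands apart. The compounds shown leave open whether bromo, fluoro, methoxy or a plain amino group on this carbon would give a number like that of compound 3.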